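This account rests on a few compounds, and the source may have more. Where it says the series, first, only, none or still open, it means among the compounds named here.

Three compounds of one series were examined in an ADME assay on HEK293 cells (Homo sapiens) for cytotoxicity, read by reporter gene assay and resazurin assay, with a stated time of 48 h; on this read-out lower numbers stand for higher toxicity in this test and higher numbers for lower toxicity in this test. Compound 3 `COc1c(Br)cccc1C(=O)Nc1ccc(Sc2nc3ccccc3s2)c(Cl)c1` gave only a limit of the assay, > 100000 nM. Compound 1 `COc1c(Br)cc(Br)cc1C(=O)Nc1ccc(Sc2nc3ccccc3s2)c(Cl)c1` differs from it by bromo in place of hydrogen on an aromatic carbon and likewise gave only a limit, > 100000 nM. The step that the two limits leave unreadable from compound 3 to compound 1 therefore stays unreadable because of the limit of > 100000 nM in this assay, at which 2 of the 3 values shown sit. Compound 2 `O=C(Nc1ccc(Sc2nc3ccccc3s2)cc1)c1cccc(Br)c1O` has a core that differs from that of compound 3 in a way not broken down here. In this assay, for the measured compounds named here, compound 2 gives 71000 nM, the only number in the set. Compound 4 `O=C(Nc1ccc(Sc2nc3ccccc3s2)cc1)c1cc(Br)cc(Br)c1O` is not yet measured; it differs from compound 2 by bromo in place of hydrogen on an aromatic carbon, the same kind of change as from compound 3 to compound 1, though here the place is para to a hydroxy group rather than para to a methoxy group. The measured pair offers no readable size to lean on. In this assay the step of a 1.4-fold lower number from compound 2 to compound 4 (0.15 log units; within the scatter) is expected, resting on compound 2 at 71000 nM. Compound 4 is estimated at 50000 nM, between 15000 nM and 150000 nM.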

Compound 4, half-maximal cytotoxic concentration: 66000 nM
For compound 4 the middle estimate is 1.3-fold (0.12 log units) below the measured one, within the range that was stated.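

In this assay, bromo in place of hydrogen on an aromatic carbon gives a 1.1-fold lower number from compound 2 to compound 4 (0.03 log units; within the scatter), so on the core of compound 2 this change shows no step beyond the usual scatter. On these data alone, the same change on the core of compound 3 gives a step that cannot be read, so whether the result carries from one core to the other stays open because both of its compounds sit at a limit of the assay: the limit of > 100000 nM in this assay, at which 2 of the 4 values shown sit. The series therefore gives a size for this change on one core only.

The compounds shown leave open how this read-out responds to another group at the place para to a hydroxy group, such as an amine or a carboxylic acid.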